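Swapping Fluoro for Hydrogen on Compound 3

This account rests on a few compounds, and the source may have more. Where it says the series, first, only, none or still open, it means among the compounds named here.

Measured so far in a functional assay on HepG2 cells (Homo sapiens) for antiproliferative activity, read by MTT assay, with a stated time of 72 h; a lower number here means a stronger inhibitor, a higher number a weaker inhibitor:
- compound 1 `O=C(N/N=C/c1ccc(Br)cc1)Nc1ccc(Oc2ccnc3[nH]ccc23)c(F)c1`: 1000 nM
- compound 2 `O=C(N/N=C/c1ccc(O)cc1O)Nc1ccc(Oc2ccnc3[nH]ccc23)c(F)c1`: 4550 nM
- compound 3 `COc1ccc(/C=N/NC(=O)Nc2ccc(Oc3ccnc4[nH]ccc34)c(F)c2)c(OC)c1OC`: 2990 nM

Compound 3 gives 2990 nM, which lies within the usual scatter of compound 2 at 4550 nM. Compound 1 at 1000 nM shows a lower number than compound 3, and that gap is beyond the scatter.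

Compound 4 `COc1ccc(/C=N/NC(=O)Nc2ccc(Oc3ccnc4[nH]ccc34)cc2)c(OC)c1OC` differs from compound 3 in a single place: hydrogen in place of fluoro on an aromatic carbon. Put simply, it has hydrogen in place of fluoro on an aromatic carbon.

Within the data shown here, the only measured single-place step is a 4.6-fold higher number from compound 1 to compound 2 (0.66 log units; beyond the scatter). That step exchanges 4-bromophenyl for 2,4-dihydroxyphenyl, a different place and a different kind of change, so it offers only a loose sense of how far numbers move in this small set. Among the measured compounds shown here, no measured pair shows what losing fluoro does, so the data give no direction. In this assay, no step beyond the scatter is therefore expected, though the uncertainty is wide. The expected step is a 1.0-fold higher number from compound 3 to compound 4 (0.00 log units; within the scatter). For compound 4 the estimated value is 3000 nM, with an expected range from 1100 nM to 8000 nM.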

Compound 4, half-maximal inhibitory concentration: 2960 nM
The estimate for compound 4 lay 1.0-fold (0.01 log units) above the measured number, and the stated range covers the measured number.
By their numbers in this assay, from the lowest: compound 1; then compounds 4, 3 and 2 (each within the scatter of the next).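

In this assay hydrogen in place of fluoro gives a 1.0-fold lower number from compound 3 to compound 4 (0.00 log units; within the scatter) and so leaves compound 3 and compound 4 indistinguishable in this measurement. Among these compounds, this pair is the first to test this aromatic carbon, and it shows that, with the rest of compound 3 held fixed, the single fluorine atom is not needed to keep the antiproliferative activity seen in these cells. Nothing measured on these compounds offers an explanation for this result.

Going by these compounds, the finding rests on one pair with a single aromatic group on the far side of the molecule, so it remains open whether the same swap would read the same way on compound 1 with its 4-bromophenyl group, or on compound 2 with its 2,4-dihydroxyphenyl group. On these data alone, it also remains open whether a larger or different group on this same carbon, such as chloro, methyl, methoxy or an amine, would match fluoro and hydrogen or move the number beyond the usual scatter.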